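Changing the group on the carbonyl carbon of compound 2

A few compounds are considered here, and "the series" means these few. Any claim that something is new, unique, unknown or untested is made for them only; others in the source may bear on it.

In a functional assay on A2780 cells (Homo sapiens) for inhibition, read by sulforhodamine B assay, with a stated time of 72 h (on this read-out lower numbers stand for stronger inhibition and higher numbers for weaker inhibition), compound 2 (`O=C(NCc1ccc(S(=O)(=O)N2CCCCC2)cc1)c1cnc2nccn2c1`) gives 130 nM and holds the higher of the two actual numbers. In this assay compound 3 (`O=C(NCc1ccc(S(=O)(=O)c2cc(F)cc(F)c2)cc1)c1cnc2nccn2c1`) gives 3 nM and so sits far lower. That gap is the step (a 43-fold lower number from compound 2 to compound 3 (1.64 log units; beyond the scatter)), with 3,5-difluorophenyl in place of piperidin-1-yl on a sulfonyl sulfur. In this assay compound 1 (`O=C(NCc1ccc(S(=O)(=O)c2ccccc2)cc1)c1nc2ccncc2s1`) reads > 10000 nM as a limit of the assay and not a number.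

Compound 4 (`O=C(NCc1ccc(S(=O)(=O)N2CCCCC2)cc1)c1ccn2cncc2c1`) keeps the piperidin-1-yl on the sulfonyl sulfur of compound 2 and changes the group on the carbonyl carbon (a group of 9 heavy atoms (7 carbon, 2 nitrogen; one five-membered aromatic ring with 2 hetero atoms, one six-membered aromatic ring with 1 hetero atom) in place of a group of 9 heavy atoms (6 carbon, 3 nitrogen; one five-membered aromatic ring with 2 hetero atoms, one six-membered aromatic ring with 2 hetero atoms), on a carbonyl carbon). For the measured compounds named here, no measured step covers this place. The only one, for compound 3 (a 43-fold lower number from compound 2 to compound 3 (1.64 log units; beyond the scatter)), lies at the sulfonyl sulfur and gives no direct guide to size or direction here. Only a modest shift, within the scatter and without a firm direction, is therefore expected (a 1.3-fold lower number from compound 2 to compound 4 (0.11 log units; within the scatter)). For compound 4 the estimated value is 100 nM in this assay, with an expected range from 20 nM to 500 nM for repeat measurements.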

Compound 4, half-maximal inhibitory concentration: > 10000 nM
Compound 4: no number, only a limit; the forecaster's own chance of this, stated with the estimate: 5%; middle value at least 100-fold (2.00 log units) away from the limit.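

The group on the carbonyl carbon proves to be a place where a small change counts, which the earlier step at the sulfonyl sulfur could not show. In this assay, trading one carbon-for-nitrogen in a two-ring group of equal heavy-atom count gives an at least 76-fold higher number from compound 2 to compound 4 (1.88 log units; beyond the scatter), even though the piperidin-1-yl on the sulfonyl sulfur stays the same. Compound 4 reads only as a limit of the assay and not as a number, so this step has a lower bound but no known full size: the limit of > 10000 nM in this assay, at which 2 of the 4 values shown sit.

From the compounds shown here alone, it remains open whether the group in compound 4 would be equally poor with 3,5-difluorophenyl on the sulfonyl sulfur. The compounds shown also leave open how a single pyridine ring or a plain phenyl ring on the carbonyl carbon would read.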